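From 4-chlorophenyl to 4-methoxyphenyl

The compounds below may be only part of what the source reports. "The series", "measured", "known", "first", "only" and "open" are said of these compounds alone.

In a functional assay on OVCAR-3 cells (Homo sapiens) for inhibition, read by MTT assay, with a stated time of 24 h (a higher number here means a weaker inhibitor, a lower number a stronger inhibitor), compound 1 `CC1(C)[C@H]2CC[C@]1(C)N(Cc1cn(-c3ccccc3)nn1)C(=O)C2` gives 50 nM while compound 2 `CC1(C)[C@H]2CC[C@]1(C)N(Cc1cn(-c3ccc(Cl)cc3)nn1)C(=O)C2` gives 160 nM which is the higher of the two numbers, so compound 2 is the weaker inhibitor of this pair. Compound 3 `COc1ccc(-n2cc(CN3C(=O)C[C@@H]4CC[C@@]3(C)C4(C)C)nn2)cc1` has not yet been measured. It carries methoxy in place of chloro on an aromatic carbon, para to a large group (methoxy in place of chloro on an aromatic carbon). For the measured compounds named here, one measured step bears on this change: chloro in place of hydrogen on an aromatic carbon gave a 3.2-fold higher number from compound 1 to compound 2 (0.51 log units; beyond the scatter) and that modest step lies beyond the scatter. Going by the values given here, no methoxy compound has been measured, so this step is only a loose guide, and no step beyond the scatter is expected, only a lean toward a lower number. The estimated change is a 1.5-fold lower number from compound 2 to compound 3 (0.16 log units; within the scatter) in this assay on this reasoning. For compound 3 the expected value is 110 nM with 40 nM to 320 nM as the expected range.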

Compound 3, half-maximal inhibitory concentration: 250 nM
The estimate for compound 3 lay 2.3-fold (0.36 log units) below the measured number; the measured number falls inside the stated range.
By their numbers in this assay, from the lowest: compound 1; then compounds 2 and 3 (each within the scatter of the next).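

In this assay, methoxy in place of chloro on the aromatic carbon para to a large group gives a 1.6-fold higher number from compound 2 to compound 3 (0.19 log units; within the scatter), so these two groups cannot be told apart at this position. Measured against hydrogen, methoxy gives a 5.0-fold higher number from compound 1 to compound 3 (0.70 log units; beyond the scatter), and alongside a 3.2-fold higher number from compound 1 to compound 2 (0.51 log units; beyond the scatter) this shows that both substituents seen here carry a higher number than the unsubstituted ring of compound 1. No available evidence accounts for this result.

The compounds shown leave open whether an amine or a carboxylic acid in this place would also give a higher number than hydrogen, or one within the scatter of compound 1. They also leave open whether a longer chain, such as ethoxy, would stay within the scatter of methoxy.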